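The compounds below may be only part of what the source reports. "The series", "measured", "known", "first", "only" and "open" are said of these compounds alone.

Measured in a functional assay on U-373MG ATCC cells (Homo sapiens), read by thymidine incorporation; on this read-out higher numbers stand for weaker inhibition and lower numbers for stronger inhibition:

Compound 1 `C=CCCC(=O)N[C@H]1[C@@H](OCCc2ccccc2)O[C@H](CO)[C@@H](O)[C@@H]1O` gives > 50 uM, a limit of this assay.
Compound 2 `CCCCCCCC/C=C\CCCCCCCC(=O)N[C@H]1[C@@H](OCCCCCCCC)O[C@H](CO)[C@@H](O)[C@@H]1O` gives 13.3 uM.
Compound 3 `C=CCCC(=O)N[C@H]1[C@@H](OCCc2ccccc2)O[C@H](CO)[C@@H](O)[C@@H]1OS(=O)(=O)O` gives > 50 uM, also a limit.

Compound 4 `CCCCCCCC/C=C\CCCCCCCC(=O)N[C@H]1[C@@H](OCCCCCCCC)O[C@H](CO)[C@@H](O)[C@@H]1OS(=O)(=O)O` is not yet measured. It differs from compound 2 by sulfo in place of hydrogen on an oxygen on a saturated carbon, the same change that leads from compound 1 to compound 3, (sulfo in place of hydrogen on an oxygen on a saturated carbon). How the core of compound 2 differs from the core of compound 1 is not broken down here. The measured step that the two limits leave unreadable from compound 1 to compound 3 is unreadable because of the limit of > 50 uM in this assay, at which 2 of the 3 values shown sit, so the change gives no readable size to carry over. Among the measured compounds shown here, compound 2 is the only compound here with a number rather than a limit. The step from compound 2 to compound 4 is therefore expected to be small, a 1.1-fold higher number from compound 2 to compound 4 (0.05 log units; within the scatter), resting on nothing more than the absence of a readable precedent. Compound 4 is estimated at 15 uM, between 4 uM and 50 uM.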

Compound 4, concentration for 50% inhibition: 15.6 uM
Beside the measured number, compound 4's estimate is 1.0-fold (0.02 log units) below it; measured number inside the range.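

In this assay, sulfo in place of hydrogen reads as a 1.2-fold higher number from compound 2 to compound 4 (0.07 log units; within the scatter), the only readable size for this change among the compounds shown. The same change on the core of compound 1 gives no size that can be set against it, so the steps on the two cores cannot be compared: the limit of > 50 uM in this assay, at which 2 of the 4 values shown sit. The result therefore describes the change on one core only and does not show that its size carries over from one core to another.

From the compounds shown here alone, whether a carboxylic acid or a phosphono group in place of the sulfo would read the same on the core of compound 2 stays open. So does the outcome of hydroxy to sulfooxy on a core with a free amine in place of the amide.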